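Swapping a halogenated phenyl ring for a methylthiophene

This account rests on a few compounds, and the source may have more. Where it says the series, first, only, none or still open, it means among the compounds named here.

Of the compounds shown here, two sharing the same tetrahydrobenzazepine-bearing sulfonamide core have been measured in an assay on isolated protein for displacement of a labelled ligand from 5-hydroxytryptamine receptor 6 (Homo sapiens), read by radioligand binding; on this read-out higher numbers stand for weaker inhibition and lower numbers for stronger inhibition. Compound 1 `CN1CCc2cc(Cl)c(NS(=O)(=O)c3ccc(-c4ccc(Cl)cc4)cc3)cc2CC1` gives 50.1 nM. Compound 2 `CN1CCc2ccc(NS(=O)(=O)c3ccc(-c4ccc(F)c(Cl)c4)cc3)cc2CC1` gives 7.94 nM in this assay, the lower of the two numbers, and the gap to compound 1 lies beyond the usual scatter. These two compounds differ in more than one place, so their numbers can only be set side by side, not read as a single step.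

Compound 3 `Cc1ccc(-c2ccc(S(=O)(=O)Nc3ccc4c(c3)CCN(C)CC4)cc2)s1` has not yet been measured. It differs from compound 2 by 5-methylthiophen-2-yl in place of 3-chloro-4-fluorophenyl on an aromatic carbon, a change that replaces the outer ring of the biaryl portion while leaving the sulfonamide and the basic core untouched. Going by the values given here, no measured pair isolates a change of this kind, so the expectation rests on the likeness of the two structures alone. The step from compound 2 to compound 3 in this assay is expected to be small, a 1.9-fold higher number from compound 2 to compound 3 (0.28 log units; within the scatter), either direction staying close to the scatter. Compound 3 is therefore estimated at 15 nM in this assay, with a likely range from 4 nM to 60 nM.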

Compound 3, inhibition constant: 6.31 nM
Compound 3: middle estimate off by 2.4-fold (0.38 log units), on the high side, within the range that was stated.
By their numbers in this assay, from the lowest: compounds 3 and 2 (each within the scatter of the next); then compound 1.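

In this assay, going by these compounds alone, this is the first change that can be read as a single step: a 1.3-fold lower number from compound 2 to compound 3 (0.10 log units; within the scatter). At this position, on an aromatic carbon para to a large group, a 3-chloro-4-fluorophenyl ring can therefore give way to a 5-methylthiophen-2-yl ring without a measurable shift in the number, even though the new ring has five members rather than six, contains sulfur and carries no halogen. No measurement here accounts for why two such different rings give numbers this close.

The compounds shown leave open how far this tolerance reaches, for instance whether an outer ring carrying a carboxylic acid or an amine would stay as close as the 5-methylthiophen-2-yl ring does. They also leave open what the methyl group contributes to the 5-methylthiophen-2-yl ring, and whether an unsubstituted thiophene or a thiophene bearing a longer chain such as propyl would give a number within the scatter of these two.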